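Changing the sulfur group of compound 3

The compounds below may be only part of what the source reports. "The series", "measured", "known", "first", "only" and "open" are said of these compounds alone.

compound 1 (`Cc1ccc(/C=C(/SCc2ccc(Cl)cc2Cl)C(=O)c2ccc(Cl)cc2)s1`): 50000 nM
compound 2 (`Cc1ccsc1/C=C(/SCc1ccc(Cl)cc1Cl)C(=O)c1ccc(Cl)cc1`): 10000 nM
compound 3 (`O=C(/C(=C\c1c[nH]c2ccc(Br)cc12)SCc1ccc(Cl)cc1Cl)c1ccc(Cl)cc1`): 10000 nM

These numbers come from a functional assay on DU-145 cells (Homo sapiens) for inhibition, read by trypan blue exclusion, with a stated time of 96 h; on this read-out higher numbers stand for weaker inhibition of growth and lower numbers for stronger inhibition of growth. Compound 3 is level with compound 2, and together they hold the lowest of the three numbers, while compound 1 stands higher.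

The next compound, compound 4 (`Cc1ccc(S/C(=C/c2c[nH]c3ccc(Br)cc23)C(=O)c2ccc(Cl)cc2)cc1`), carries 4-methylphenyl in place of 2,4-dichlorobenzyl on a sulfur.

All three measured steps change a different place, the group on a double-bonded chain carbon. Two of them are modest: a 5.0-fold lower number from compound 1 to compound 2 (0.70 log units; beyond the scatter) and a 5.0-fold lower number from compound 1 to compound 3 (0.70 log units; beyond the scatter). The third shows no change at the digits printed from compound 2 to compound 3 (within the scatter). Among the compounds with values here, no measured step touches the group on the sulfur, so the data give neither a size nor a direction for this change. The best starting point is therefore compound 3 itself, at 10000 nM, and the range must stay wide enough for a modest move either way.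

The expected outcome, with no step beyond the scatter, is no change at the digits printed from compound 3 to compound 4 (within the scatter).

For compound 4 the estimate is 10000 nM, with an expected range from 3000 nM to 35000 nM.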

Compound 4, concentration for 50% growth inhibition: 1000 nM
Beside the measured number, compound 4's estimate is 10-fold (1.00 log units) above it; measured number outside the range, below it.
By their numbers in this assay, from the lowest: compound 4; then compounds 2 and 3 (each within the scatter of the next); then compound 1.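

In this assay, the group on the sulfur proves to be a position that responds: 4-methylphenyl in place of 2,4-dichlorobenzyl gives a 10-fold lower number from compound 3 to compound 4 (1.00 log units; beyond the scatter), so growth inhibition gets stronger with this change. The earlier compounds shown here varied only the group on the double-bonded chain carbon, so they could show neither that the sulfur group matters nor in which direction a change there would go. This single step removes both chlorine atoms and also replaces the benzyl group with a methyl-bearing phenyl group, and no other data here explain the gain or assign it to either part of the change.

On these data alone, it remains open which part of the swap carries the gain, a question that an unsubstituted phenyl, a 4-chlorophenyl or a plain benzyl group on the sulfur could help to separate, while an amine, a carboxylic acid or a longer chain on that sulfur would test how much variety the position accepts. As far as these compounds go, it is also open whether 4-methylphenyl would give a similar step with 3-methylthiophen-2-yl in place of 5-bromo-1H-indol-3-yl on the double-bonded chain carbon.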